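Thiosemicarbazone series: cytotoxicity notes, compound 2 to compound 3

A few compounds are considered here, and "the series" means these few. Any claim that something is new, unique, unknown or untested is made for them only; others in the source may bear on it.

compound 1 `O=C1Nc2ccc(OC(F)(F)F)cc2/C1=N/NC(=S)Nc1ccccc1` — > 25000 nM
compound 2 `CCN1C(=O)/C(=N\NC(=S)Nc2ccccc2)c2ccccc21` — > 25000 nM

In an ADME assay on RD cells (Homo sapiens) for cytotoxicity (a lower number here means that less compound is tolerated, a higher number that more compound is tolerated), compound 1 reaches only the limit of the assay, > 25000 nM. In this assay compound 2 likewise gives only a limit, > 25000 nM. Both values sit at the limit of > 25000 nM in this assay, at which 2 of the 2 values shown sit, so compound 2 stands where compound 1 stands and no number separates the two. Compound 3 `O=C1/C(=N\NC(=S)Nc2ccccc2)c2ccccc2N1Cc1ccccc1` differs from compound 2 in one place: phenyl in place of methyl on a saturated chain carbon bound to an amide-type nitrogen in a ring. Among the compounds with values here, no step between two measured compounds is available in this assay to gauge what this change does, and the two measured values give no direction either. The expected step is a step that the limit leaves unreadable from compound 2 to compound 3, none beyond the scatter, with the result most likely again reported as a limit. Compound 3 is estimated at 30000 nM in this assay, with a range from 12000 nM to 80000 nM.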

Compound 3, half-maximal cytotoxic concentration: > 25000 nM
Compound 3: a limit, no number; the forecaster's own chance of this, stated with the estimate: 70%; the middle value lies beyond the limit too.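

No step can be read from compound 2 to compound 3 in this assay, since both values are limits: the limit of > 25000 nM in this assay, at which 3 of the 3 values shown sit.

The compounds shown leave open what concentration of compound 1, compound 2 or compound 3 is tolerated, and whether phenyl in place of methyl changes it.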